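Nitrooxy chain esters: the step to compound 4

The compounds below may be only part of what the source reports. "The series", "measured", "known", "first", "only" and "open" are said of these compounds alone.

In a functional assay on H266 cells (Homo sapiens) for cytotoxicity, read by resazurin assay, with a stated time of 72 h; a higher number here means a weaker inhibitor, a lower number a stronger inhibitor:
- Compound 1 `COc1cc(/C=C/C(=O)OCCCCCCO[N+](=O)[O-])ccc1O`: > 50000 nM, a limit of the assay
- Compound 2 `COc1cc(/C=C/C(=O)OCCCCCO[N+](=O)[O-])ccc1O`: 21200 nM
- Compound 3 `COc1cc(/C=C/C(=O)OCCCO[N+](=O)[O-])ccc1O`: 44000 nM

Compound 3, at 44000 nM, holds the higher of the two actual numbers in this assay, and compound 2 is the only other one.

Compound 4 `COc1cc(/C=C/C(=O)OC/C=C/CO[N+](=O)[O-])ccc1O` differs from compound 3 on a saturated chain carbon bound to an oxygen next to a carbonyl group: a group of 7 heavy atoms (3 carbon, 1 nitrogen, 3 oxygen; no ring) in place of a group of 6 heavy atoms (2 carbon, 1 nitrogen, 3 oxygen; no ring), on a saturated chain carbon bound to an oxygen next to a carbonyl group.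

Within the data shown here, the steps that bear on this change are those in the same chain: a 2.1-fold higher number from compound 2 to compound 3 (0.32 log units; beyond the scatter), which is modest, and an at least 2.3-fold lower number from compound 1 to compound 2 (0.37 log units; beyond the scatter), at least modest. The floor of an at least 1.1-fold lower number from compound 1 to compound 3 (0.05 log units; that floor lies within the scatter) lies within the scatter. These steps do not run in one direction with chain length, and compound 2 goes against any simple trend. None of them introduces a further double bond, so they suggest a size of step but no firm direction. The expected step is small, a 1.5-fold lower number from compound 3 to compound 4 (0.17 log units; within the scatter), and no change beyond the scatter is expected. For compound 4 the estimated value is 30000 nM, with an expected range of 12000 nM to 50000 nM.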

Compound 4, half-maximal inhibitory concentration: 9790 nM
Compound 4: the middle estimate sits 3.1-fold (0.49 log units) above what was measured; the whole stated range lies above it.
By their numbers in this assay, from the lowest: compound 4; then compound 2; then compound 3. At a limit, above all of these: compound 1.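

The earlier steps shown here only varied the length of a saturated nitrooxy chain, and they did not run in one direction. In this assay, the group entering on the saturated chain carbon bound to an oxygen next to a carbonyl group, with 2 double bonds outside aromatic rings in place of 1, gives a 4.5-fold lower number from compound 3 to compound 4 (0.65 log units; beyond the scatter), so this position responds to more than the saturated series showed, although the change adds a heavy atom and a double bond together and the two cannot be told apart here. No measurement shown accounts for this step.

A 4-(nitrooxy)butyl chain would leave open how much of the step belongs to the double bond itself. Also open, as far as these compounds go, are a chain with a carbon-carbon triple bond and a hydroxyl in place of the nitrooxy group.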